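The source may report more compounds than this note shows. Statements on the series, on what has been measured and on what is new or still open speak of the compounds shown alone.

Compound 3, `C[S+]([O-])c1ccc(N2C(=O)C(C)(C)c3cccnc32)cc1`, was tested in a functional assay on the whole organism (Pleural cavity) for inhibition, with Rattus norvegicus as the target, at a dose of 25 mg/kg (on this read-out lower numbers stand for less inhibition and higher numbers for more inhibition at the one dose given (going by the name of the read-out)), where compound 3 gives 39%. Two close relatives share its core. Compound 1, `CC1(C)C(=O)N(c2ccc(S(C)(=O)=O)cc2)c2ncccc21`, gives 42% in this assay, and compound 2, `CSc1ccc(N2C(=O)C(C)(C)c3cccnc32)cc1`, gives 29%. Among these three numbers compound 3 stands second highest; its nearest neighbour is compound 1, with the gap a number 3 percentage points lower from compound 1 to compound 3 (within the scatter) lying within the scatter, and its furthest is compound 2, with the gap a number 10 percentage points higher from compound 2 to compound 3 (within the scatter) also within the scatter. The only difference that reaches beyond the scatter is a number 13 percentage points lower from compound 1 to compound 2 (beyond the scatter).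

Compound 4, `CC(C)c1ccc(N2C(=O)C(C)(C)c3cccnc32)cc1`, has not yet been measured in this assay. It differs from compound 3 by a group of 3 heavy atoms (3 carbon; no ring) in place of a group of 3 heavy atoms (1 carbon, 1 oxygen, 1 sulfur; no ring), on an aromatic carbon. Among the compounds with values here, the steps that bear on this swap all exchange a small group on the same aromatic carbon: a number 3 percentage points lower from compound 1 to compound 3 (within the scatter) and a number 10 percentage points higher from compound 2 to compound 3 (within the scatter) stayed within the scatter, while a number 13 percentage points lower from compound 1 to compound 2 (beyond the scatter) went beyond it. The incoming isopropyl, like the methylsulfanyl of compound 2, carries no hydrogen-bond acceptor, and compound 2 gives 29%. A small downward step is therefore expected, a number 9 percentage points lower from compound 3 to compound 4 (within the scatter), not clearly beyond the scatter. Compound 4 is estimated at 30%, within a range from 15% to 45%.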

Compound 4, a percentage reported as inhibition, in the whole organism at one dose (the size of the read-out at that dose, not a potency): 29%
For compound 4 the middle estimate is 1 percentage points above the measured one; the range from low to high includes it.
By their numbers in this assay, from the lowest: compounds 2, 4, 3 and 1 (each within the scatter of the next, the first and the last beyond it).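

In this assay, replacing methylsulfonyl with isopropyl gives a number 13 percentage points lower from compound 1 to compound 4 (beyond the scatter), a step of the same printed size as the one already seen for methylsulfanyl, a number 13 percentage points lower from compound 1 to compound 2 (beyond the scatter), so this loss does not depend on keeping a sulfur atom on this aromatic carbon. Isopropyl and methylsulfanyl cannot be told apart here, with no change at the digits printed from compound 2 to compound 4 (within the scatter), and replacing the group of compound 3 with isopropyl gives a number 10 percentage points lower from compound 3 to compound 4 (within the scatter), so compound 3 cannot be separated from either of them. No measurement is available to explain why these groups compare as they do.

The compounds shown leave open whether a group such as an amine, a carboxylic acid or a sulfonamide on this aromatic carbon would give a number closer to that of compound 1 or to that of compound 4. They also leave open whether a longer chain, such as n-butyl, would stay level with isopropyl, and how these groups would compare at doses other than the single one used here.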